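Two Stereoisomers at the Limit, and a Longer Chain

The source may report more compounds than this note shows. Statements on the series, on what has been measured and on what is new or still open speak of the compounds shown alone.

In a functional assay on MGC-803 cells (Homo sapiens) for antiproliferative activity, read by MTT assay, with a stated time of 48 h (on this read-out lower numbers stand for stronger inhibition and higher numbers for weaker inhibition), compound 1 (`CCCCCCCn1cc(COC[C@@H]2OC[C@H](N)[C@@H]2O)nn1`) reads > 128000 nM as a limit of the assay. Compound 2 (`CCCCCCCn1cc(COC[C@@H]2OC[C@H](N)[C@H]2O)nn1`) likewise reads > 128000 nM as a limit and gives no number. Within the data shown here, the one measured step (a step that the two limits leave unreadable from compound 1 to compound 2) has no readable size, so it offers no size to carry forward. Compound 3 (`CCCCCCCCCn1cc(COC[C@@H]2OC[C@H](N)[C@H]2O)nn1`) differs from compound 2 by ethyl in place of hydrogen on a saturated chain carbon, seven bonds along the chain from an aromatic nitrogen on the chain. A step toward stronger inhibition is expected, though the data fix no size for it. The estimated change in this assay is an at least 1.8-fold lower number from compound 2 to compound 3 (0.26 log units; that floor lies within the scatter) and remains uncertain. For compound 3 the expected value is 70000 nM with an estimated range from 20000 nM to 150000 nM on this read-out.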

Compound 3, half-maximal inhibitory concentration: > 128000 nM
Compound 3 ended at the assay's limit (the forecaster's own chance of this, stated with the estimate: 45%); middle value at least 1.8-fold (0.26 log units) from the limit.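

In this assay compound 3 gives > 128000 nM, which is a limit, so no step can be read from compound 2 to compound 3. The compounds shown leave open whether any chain or configuration on the shared core gives a readable value.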